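The compounds below may be only part of what the source reports. "The series", "measured", "known", "first", "only" and "open" are said of these compounds alone.

Working notes on the series. The set comprises compound 1 `COc1cccc(C(=O)Oc2cc3c(cc2C)[C@@H](C(C)C)CC=C3C)c1`, compound 2 `CC1=CC[C@H](C(C)C)c2cc(C)c(OC(=O)c3ccccc3)cc21` and compound 3 `CC1=CC[C@H](C(C)C)c2cc(C)c(OC(=O)c3cccc(Cl)c3)cc21`, all sharing one core and differing only in the group on the aromatic ring of the ester. In a functional assay on MCF7 cells (Homo sapiens) for antiproliferative activity, read by sulforhodamine B assay, with a stated time of 48 h, tested at 50 uM (a higher number here means more inhibition at the concentration tested (going by the name of the read-out), a lower number less inhibition), compound 2 gives 60.7%, compound 3 gives 40.4% and compound 1 gives 11.9%. Compound 3 therefore stands second highest of the three numbers: its nearest neighbour is compound 2, with a number 20.3 percentage points lower from compound 2 to compound 3 (beyond the scatter), and the furthest is compound 1, with a number 28.5 percentage points higher from compound 1 to compound 3 (beyond the scatter). The remaining step, a number 48.8 percentage points higher from compound 1 to compound 2 (beyond the scatter), shows the widest span in the set.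

Compound 4 `CC1=CC[C@H](C(C)C)c2cc(C)c(OC(=O)c3cccc(C(F)(F)F)c3)cc21` is not yet measured. The change from compound 3 is trifluoromethyl in place of chloro on an aromatic carbon. For the measured compounds named here, no measured step exchanges chloro for trifluoromethyl, so the only guidance is that the same aromatic carbon has so far carried hydrogen, chloro and methoxy, and that replacing hydrogen by chloro gave the modest drop seen in a number 20.3 percentage points lower from compound 2 to compound 3 (beyond the scatter), while replacing methoxy by chloro gave the modest rise seen in a number 28.5 percentage points higher from compound 1 to compound 3 (beyond the scatter). A further group of four heavy atoms entering in place of chloro is expected to leave the number near that of compound 3 or somewhat lower, within the scatter to modest. For compound 4 the expected step is a number 5.4 percentage points lower from compound 3 to compound 4 (within the scatter). Compound 4 is thus estimated at 35% in this assay, with a range from 15% to 55%.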

Compound 4, a percentage reported as inhibition, at one concentration (the size of the read-out at that concentration, not a potency): 86%
Compound 4: the middle estimate sits 51 percentage points below what was measured; measured number above the stated range.
By their numbers in this assay, from the lowest: compound 1; then compound 3; then compound 2; then compound 4.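

In this assay, for the compounds shown here, the earlier compounds left hydrogen ahead of both chloro and methoxy on this aromatic carbon, but trifluoromethyl overturns that picture (a number 25.3 percentage points higher from compound 2 to compound 4 (beyond the scatter)), showing that a group here can raise the number as well as lower it. The exchange of chloro for trifluoromethyl, neither of which carries a hydrogen-bond donor or acceptor, is itself a large step (a number 45.6 percentage points higher from compound 3 to compound 4 (beyond the scatter)), so these two groups are not interchangeable at this carbon, and the span between methoxy and trifluoromethyl now reaches further than any earlier step (a number 74.1 percentage points higher from compound 1 to compound 4 (beyond the scatter)). No supporting measurement bears on what lies behind the resulting order of compound 4, compound 2, compound 3 and compound 1.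

The compounds shown leave open where other groups on this carbon would fall, such as a nitrile, an amine, a carboxylic acid or a longer chain, and whether trifluoromethyl would give a similar number on another carbon of this ring. Each number also comes from a single concentration, so the relative potency of these compounds remains open.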